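A methoxy to hydroxy step on the shared core

This account rests on a few compounds, and the source may have more. Where it says the series, first, only, none or still open, it means among the compounds named here.

Compound 1 `COc1c(O)cc2occ(-c3csc4ccccc34)c(=O)c2c1O`: > 10000 nM (a limit of the assay)
Compound 2 `COc1cc2occ(-c3csc4ccccc34)c(=O)c2c(OC)c1OC`: 640 nM

Both compounds were tested in a functional assay on A549 cells (Homo sapiens) for antiproliferative activity, read by sulforhodamine B assay, with a stated time of 72 h; a higher number here means a weaker inhibitor, a lower number a stronger inhibitor. Among the measured compounds shown here, compound 2 stands alone as the only one with an actual number, 640 nM. Compound 1 sits at a limit, > 10000 nM.

Compound 3 `COc1cc2occ(-c3csc4ccccc34)c(=O)c2c(OC)c1O` has not yet been measured. It departs from compound 2 at a single place: hydrogen in place of methyl on an oxygen on an aromatic ring. This puts hydrogen in place of methyl on an oxygen on an aromatic ring, a methoxy to hydroxy change. With only two results to go on, and one of them a limit, a moderate step towards weaker inhibition is expected in this assay, though the direction is far from certain. The expected size is a 2.3-fold higher number from compound 2 to compound 3 (0.37 log units; beyond the scatter). For compound 3 the estimate is 1500 nM, with an expected range from 300 nM to 8000 nM.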

Compound 3, half-maximal inhibitory concentration: > 10000 nM
Compound 3 was reported as a limit; the forecaster's own chance of this, stated with the estimate: 12%; middle value at least 6.6-fold (0.82 log units) away from the limit.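

In this assay, among the compounds shown here, replacing methyl with hydrogen on an oxygen on an aromatic ring gives an at least 15-fold higher number from compound 2 to compound 3 (1.19 log units; beyond the scatter), the first evidence that this single methoxy to hydroxy change on the shared core is enough to move the result by a large margin. Compound 3 gives > 10000 nM, which is a limit of the assay and not a number. The full size of the step therefore stays unknown, because compound 3 rests at the limit of the assay: the limit of > 10000 nM in this assay, at which 2 of the 3 values shown sit.

The compounds shown leave open whether it is the methyl itself that counts at this place or any group carried on this oxygen. An ethoxy or a longer chain on the oxygen, or an amine in place of the methoxy, would be needed to tell these apart.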